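The source may hold more compounds than are shown below. What is called first, only, known or untested is meant among the compounds shown, and "the series" means these compounds.

Working notes on the series. The shared core carries a propenone bridge between an aryl ketone and a pyrazole bearing a second aryl group. Compound 1 `COc1ccc(-c2cc(/C=C/C(=O)c3ccc(N)cc3)[nH]n2)cc1` gives 5840 nM in a functional assay on UACC-62 cells (Homo sapiens) for inhibition, read by sulforhodamine B assay, with a stated time of 48 h; on this read-out higher numbers stand for lower toxicity in this test and lower numbers for higher toxicity in this test. Compound 2 `COc1cc(-c2cc(/C=C/C(=O)c3ccc(N)cc3)[nH]n2)cc(OC)c1OC` gives 7510 nM in this assay. Compound 3 `COc1ccc(C(=O)/C=C/c2cc(-c3cc(OC)c(OC)c(OC)c3)n[nH]2)cc1OC` gives 5980 nM in this assay. Compound 2 shows the highest number of the three, but its gap to compound 3 and its gap to compound 1 are both within the scatter, so no ordering among them can be read off; the three compounds sit together.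

The unmeasured compound 4 `COc1ccc(-c2cc(/C=C/C(=O)c3ccc(N)cc3)[nH]n2)cc1OC` differs from compound 2 by hydrogen in place of methoxy on an aromatic carbon. Within the data shown here, the only single-point step measured so far is a 1.3-fold lower number from compound 2 to compound 3 (0.10 log units; within the scatter), which concerns the aryl on the carbonyl carbon rather than a methoxy group and therefore bears only loosely on the present change. Compound 1 and compound 2, which differ in their methoxy pattern, give values within the scatter of each other, which is the nearest indication that removing one methoxy group leaves the number roughly in place. In this assay compound 4 is therefore expected to sit at 6500 nM, between 3200 nM and 13000 nM. The expected step is a 1.2-fold lower number from compound 2 to compound 4 (0.06 log units; within the scatter), which is no step beyond the scatter.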

Compound 4, concentration lethal to 50% of the cells: 39600 nM
Compound 4: middle estimate off by 6.1-fold (0.78 log units), on the low side; the measured number lies above the stated range.
By their numbers in this assay, from the lowest: compounds 1, 3 and 2 (each within the scatter of the next); then compound 4.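

In this assay hydrogen in place of methoxy on this aromatic carbon gives a 5.3-fold higher number from compound 2 to compound 4 (0.72 log units; beyond the scatter) and methoxy in place of hydrogen on the same ring gives a 6.8-fold higher number from compound 1 to compound 4 (0.83 log units; beyond the scatter) with compound 4 standing apart on the side of lower toxicity in this test. The earlier compounds shown here gave no sign of this sensitivity: compound 1 and compound 2 sit within the scatter of each other, so their values alone suggested that the methoxy pattern on this ring hardly mattered. Among these three compounds the number does not follow the count of methoxy groups in one direction, since compound 4, with the intermediate count, lies beyond the scatter from both compound 1 and compound 2, so a methoxy group ortho to a methoxy group and meta to a large group has to be read within the whole pattern on the ring.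

On these data alone, whether a hydroxyl group, a fluorine atom or an ethoxy group at this place would keep the number of compound 4 stays open, as does whether the same pattern holds with 3,4-dimethoxyphenyl in place of 4-aminophenyl on a carbonyl carbon. Nothing in the data at hand accounts for the separation of compound 4.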